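A phenyl swap from compound 3 to compound 4

A few compounds are considered here, and "the series" means these few. Any claim that something is new, unique, unknown or untested is made for them only; others in the source may bear on it.

Of the compounds shown here, three built on one shared core have been measured in a functional assay on MCF7 cells (Homo sapiens) for cytotoxicity, read by MTT assay, with a stated time of 48 h; a higher number here means a weaker inhibitor, a lower number a stronger inhibitor. Compound 1 `O=C(CSc1nnc(-c2ccncc2)o1)N/N=C/c1ccc(F)cc1` gives 13500 nM, compound 2 `O=C(CSc1nnc(-c2ccncc2)o1)N/N=C/c1ccc(Br)cc1` gives 19100 nM, and compound 3 `O=C(CSc1nnc(-c2ccncc2)o1)N/N=C/c1cccc(F)c1` gives 24900 nM. None of the steps among them, a 1.8-fold higher number from compound 1 to compound 3 (0.27 log units; within the scatter), a 1.3-fold higher number from compound 2 to compound 3 (0.12 log units; within the scatter) or a 1.4-fold higher number from compound 1 to compound 2 (0.15 log units; within the scatter), reaches beyond the scatter, so compound 3 stands level with the other two. Compound 4 `O=C(CSc1nnc(-c2ccncc2)o1)N/N=C/c1cc(Cl)ccc1O` differs from compound 3 in one place: 5-chloro-2-hydroxyphenyl in place of 3-fluorophenyl on a carbon with a double bond to nitrogen. Every measured step exchanges the group on the same carbon with a double bond to nitrogen, and none moved this assay beyond the scatter; the same is expected here. Compound 4 is therefore estimated at 22000 nM, within 7000 nM to 70000 nM, an expected step of a 1.1-fold lower number from compound 3 to compound 4 (0.05 log units; within the scatter).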

Compound 4, half-maximal inhibitory concentration: 5830 nM
Compound 4: middle estimate off by 3.8-fold (0.58 log units), on the high side, outside the stated range (below it).
By their numbers in this assay, from the lowest: compound 4; then compounds 1, 2 and 3 (each within the scatter of the next).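

In this assay, the group on this carbon with a double bond to nitrogen proves able to move the number beyond the scatter, which no earlier exchange did: 5-chloro-2-hydroxyphenyl gives (a 4.3-fold lower number from compound 3 to compound 4 (0.63 log units; beyond the scatter)), (a 3.3-fold lower number from compound 2 to compound 4 (0.52 log units; beyond the scatter)) and (a 2.3-fold lower number from compound 1 to compound 4 (0.36 log units; beyond the scatter)). This single change brings in a chloro and a hydroxy group together, so the step belongs to the whole 5-chloro-2-hydroxyphenyl group and not to either one alone. Nothing measured here accounts for the step. The compounds shown leave open whether the chloro or the hydroxy group carries the step, and whether a methoxy group or an amine in place of the hydroxy would keep it.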